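This account rests on a few compounds, and the source may have more. Where it says the series, first, only, none or still open, it means among the compounds named here.

Measured so far in a functional assay on MKN-45 cells (Homo sapiens) for cytotoxicity, read by MTT assay, with a stated time of 72 h; on this read-out lower numbers stand for stronger inhibition and higher numbers for weaker inhibition: compound 1 `COc1cc2c(Oc3ccc(NC(=O)c4cn(-c5c(C)cccc5C)nn4)cc3F)ccnc2cc1OCCCN1CCCC1` gives 3490 nM; compound 2 `COc1cc2c(Oc3ccc(NC(=O)c4cn(-c5ccccc5F)nn4)cc3F)ccnc2cc1OCCCN1CCCCC1` gives 1290 nM; compound 3 `COc1cc2c(Oc3ccc(NC(=O)c4cn(-c5ccc(Br)cc5)nn4)cc3F)ccnc2cc1OCCCN1CCCCC1` gives 150 nM.

Compound 3 holds the lowest number of the three, with compound 2 nearest to it and compound 1 furthest away. Compound 4 `COc1cc2c(Oc3ccc(NC(=O)c4cn(-c5c(C)cccc5C)nn4)cc3F)ccnc2cc1OCCCN1CCCCC1` differs from compound 3 by 2,6-dimethylphenyl in place of 4-bromophenyl on an aromatic nitrogen. Going by the values given here, one measured step touches the same position: an 8.6-fold lower number from compound 2 to compound 3 (0.93 log units; beyond the scatter). Among the compounds with values here, compound 4 also carries the same 2,6-dimethylphenyl as compound 1, which in this assay gave 3490 nM; compound 1 and compound 4 differ only in the ring at the end of the chain, and no step for that change is on hand. The number is therefore expected to rise clearly, a 17-fold higher number from compound 3 to compound 4 (1.22 log units; beyond the scatter). The estimate for compound 4 is 2500 nM, within 800 nM to 8000 nM.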

Compound 4, half-maximal inhibitory concentration: 2140 nM
Compound 4: middle estimate off by 1.2-fold (0.07 log units), on the high side; low and high end bracket the measured number.
By their numbers in this assay, from the lowest: compound 3; then compounds 2, 4 and 1 (each within the scatter of the next, the first and the last beyond it).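

There is a 14-fold higher number from compound 3 to compound 4 (1.15 log units; beyond the scatter) in this assay with 2,6-dimethylphenyl in place of 4-bromophenyl, so the low number of compound 3 does not carry over to every substituted phenyl at this position. There is only a 1.7-fold higher number from compound 2 to compound 4 (0.22 log units; within the scatter) when 2,6-dimethylphenyl replaces 2-fluorophenyl, which leaves 4-bromophenyl alone in standing out among the three groups. There is also only a 1.6-fold lower number from compound 1 to compound 4 (0.21 log units; within the scatter) on going from pyrrolidin-1-yl to piperidin-1-yl, so with 2,6-dimethylphenyl in place that ring swap shows no clear effect. On these data alone, whether 4-chlorophenyl or 4-methoxyphenyl would keep the low number stays open. Nothing on hand explains these differences.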